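The source may report more compounds than this note shows. Statements on the series, on what has been measured and on what is new or still open speak of the compounds shown alone.

Of the compounds shown here, two have been measured in an assay on isolated protein for inhibition of Rho-associated protein kinase 1 (Homo sapiens), read by scintillation counting, radiometric assay and 33P incorporation, with a stated time of 40 min, in the presence of a further agent that is not named here; on this read-out lower numbers stand for stronger inhibition and higher numbers for weaker inhibition. Compound 1, `CN(C)c1ccc(C(=O)Nc2cccc(NC(=O)COc3ccc4c(c3)OCCO4)c2)cc1`, reaches only the limit of the assay: in this assay compound 1 gives > 10000 nM, which is a limit and not a number. Compound 2, `N#Cc1ccc(C(=O)Nc2cccc(NC(=O)COc3ccc4c(=O)ccoc4c3)c2)cc1`, gives 123 nM in this assay. Compound 2 therefore stands as the only compound in this set with an actual number; the single other result is a limit, as shown by the limit of > 10000 nM in this assay, at which 1 of the 2 values shown sits. For the measured compounds named here, no pair of measured compounds differs in just one place, so no measured step is available to lean on.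

The next compound, compound 3, is `Nc1ccc(C(=O)Nc2cccc(NC(=O)COc3ccc4c(=O)ccoc4c3)c2)cc1`. It differs from compound 2 in one place: amino in place of cyano on an aromatic carbon. Going by the values given here, with no comparable measured step, the size of this change in this assay can only be guessed. The expectation is a small step from compound 2 to compound 3, estimated at a 2.4-fold higher number from compound 2 to compound 3 (0.39 log units; beyond the scatter), toward weaker inhibition, but not far beyond the usual scatter. On that basis compound 3 is expected to give about 300 nM in this assay, estimated to fall between 80 nM and 1500 nM.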

Compound 3, half-maximal inhibitory concentration: 802 nM
For compound 3 the middle estimate is 2.7-fold (0.43 log units) below the measured one; the range from low to high includes it.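

For the compounds shown here, this is the first measured step at this position: in this assay, the change from 4-cyanophenyl to 4-aminophenyl gives a 6.5-fold higher number from compound 2 to compound 3 (0.81 log units; beyond the scatter), toward weaker inhibition. The group on this aromatic carbon, para to a large group, therefore matters, since exchanging this one group moves the result beyond the usual scatter, yet the amino compound still gives a real number and not a limit. Nothing measured here bears on why the amino group gives the weaker result, so the step records the size of the change and not its cause.

Going by these compounds alone, with only two groups compared at this position, no trend can be drawn, and it remains open whether a plain hydrogen, a methoxy group, a chlorine atom or a carboxylic acid in the same place would give a number closer to that of compound 2 or of compound 3. Compound 1 differs from both of these compounds in more than one place, so no step to it can be read, and the effect of a dimethylamino group on this exact core also stays open.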